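Lengthening the chain on the aromatic nitrogen

The source may report more compounds than this note shows. Statements on the series, on what has been measured and on what is new or still open speak of the compounds shown alone.

Compound 1, `COc1ccc([N+](=O)[O-])cc1CSc1nc2cc(NC(=O)NC(C)(C)C)ccc2n1C1CC1`, in an assay on isolated protein for inhibition of Gonadotropin-releasing hormone receptor (Rattus norvegicus) (on this read-out higher numbers stand for weaker inhibition and lower numbers for stronger inhibition), gives 860 nM.
Compound 2, `CCn1c(SCc2cc([N+](=O)[O-])ccc2OC)nc2cc(NC(=O)NC(C)(C)C)ccc21`, in this assay gives 170 nM.
Compound 3, `CCCCn1c(SCc2cc([N+](=O)[O-])ccc2OC)nc2cc(NC(=O)NC(C)(C)C)ccc21`, in this assay gives 330 nM.

Compound 3 stands second highest of these three numbers: it lies close to compound 2, with a 1.9-fold higher number from compound 2 to compound 3 (0.29 log units; within the scatter), and further from compound 1, with a 2.6-fold lower number from compound 1 to compound 3 (0.42 log units; beyond the scatter). Compound 4, `CCCCCn1c(SCc2cc([N+](=O)[O-])ccc2OC)nc2cc(NC(=O)NC(C)(C)C)ccc21`, differs from compound 3 by methyl in place of hydrogen on a saturated chain carbon, four bonds along the chain from an aromatic nitrogen. Among the compounds with values here, the only step that bears directly on this change is the chain extension from compound 2 to compound 3, which stayed within the scatter; the steps from compound 1 compare a ring with a chain and are less telling. A further step of no more than the scatter is therefore expected, written as a 1.2-fold higher number from compound 3 to compound 4 (0.08 log units; within the scatter). Compound 4 is estimated to give 400 nM, within 180 nM to 900 nM.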

Compound 4, half-maximal inhibitory concentration: 880 nM
The estimate for compound 4 lay 2.2-fold (0.34 log units) below the measured number; the measured number falls inside the stated range.
By their numbers in this assay, from the lowest: compounds 2 and 3 (each within the scatter of the next); then compounds 1 and 4 (each within the scatter of the next).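

In this assay, the single added methyl counts for more than its size suggests: a 2.7-fold higher number from compound 3 to compound 4 (0.43 log units; beyond the scatter) lies beyond the scatter, whereas ethyl and butyl stayed within it. The pentyl chain also separates clearly from the ethyl chain, with a 5.2-fold higher number from compound 2 to compound 4 (0.71 log units; beyond the scatter) as the step between them. At a 1.0-fold higher number from compound 1 to compound 4 (0.01 log units; within the scatter) the pentyl chain cannot be told apart from the cyclopropyl group, and nothing here explains these differences. Still open, on these data alone, is whether a hexyl chain would raise the number further, and whether an amine at the chain end would change this picture.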